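The source may report more compounds than this note shows. Statements on the series, on what has been measured and on what is new or still open speak of the compounds shown alone.

Measured so far in a functional assay on SMMC-7721 cells (Homo sapiens) for antiproliferative activity, read by CCK-8 assay, with a stated time of 72 h; on this read-out lower numbers stand for stronger inhibition and higher numbers for weaker inhibition:
- Compound 1 `Nc1ccccc1NC(=O)c1ccc(CSC(=S)N2CCN(c3ccccc3)CC2)cc1`: 2860 nM
- Compound 2 `Nc1ccccc1NC(=O)c1ccc(CSC(=S)N2CCc3cc(Cl)ccc32)cc1`: 1880 nM

Both compounds share the same core and differ in the group attached at one end. Within the data shown here, with only two compounds measured, there is little to compare. Compound 1 at 2860 nM and compound 2 at 1880 nM lie within the usual scatter of repeated measurements, so this pair cannot be ranked.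

The next compound is compound 3 `Nc1ccccc1NC(=O)c1ccc(CSC(=S)N2CCN(c3ccncc3)CC2)cc1`. It keeps the whole of compound 1 except for one swap: pyridin-4-yl in place of phenyl on an amine nitrogen in a ring. The two groups are the same size in heavy atoms, and the change is a single ring atom.

Among the measured compounds shown here, no measured pair here differs in only one place, so this assay offers no direct precedent for this swap. For the measured compounds named here, the only guide is that, despite a larger structural difference from compound 1, compound 2 gives 1880 nM. On that thin basis, the expected step is a 1.2-fold lower number from compound 1 to compound 3 (0.08 log units; within the scatter), which is not expected to exceed the scatter in either direction. For compound 3 the estimated value is 2400 nM, with an expected range from 800 nM to 7000 nM.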

Compound 3, half-maximal inhibitory concentration: 1340 nM
Estimate against measurement, compound 3: 1.8-fold (0.25 log units) above; the range from low to high includes it.
By their numbers in this assay, from the lowest: compounds 3, 2 and 1 (each within the scatter of the next, the first and the last beyond it).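

In this assay, replacing phenyl with pyridin-4-yl on the amine nitrogen in the six-membered ring gives a 2.1-fold lower number from compound 1 to compound 3 (0.33 log units; beyond the scatter). Among these compounds, this is the first comparison here in which only one place changes, and it shows that this position responds modestly to a small edit: the heavy-atom count stays the same, while one ring carbon becomes a nitrogen and the group gains one hydrogen-bond acceptor where phenyl had none. No measurement shown here explains the step, so it cannot be assigned to any particular property of the new ring.

This single pair cannot show whether the gain depends on where the nitrogen sits in the ring, a question that pyridin-3-yl or pyridin-2-yl on the same amine nitrogen would address. It also leaves open whether an aromatic ring is needed at this position at all, which a group such as cyclohexyl or a simple methyl would help to answer.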